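The source may hold more compounds than are shown below. What is called first, only, known or untested is meant among the compounds shown, and "the series" means these compounds.

Compound 1 `COc1cc(-c2cc(/C=C/C(=O)c3ccc(N)cc3)[nH]n2)cc(OC)c1OC` and compound 2 `COc1ccc(C(=O)/C=C/c2cc(-c3cc(OC)c(OC)c(OC)c3)n[nH]2)cc1OC` share one core and differ only in the aryl group on the carbonyl carbon. In a functional assay on OVCAR-3 cells (Homo sapiens) for cytotoxicity, read by sulforhodamine B assay, with a stated time of 48 h, tested at 1 uM (a lower number here means a stronger effect, a higher number a weaker effect of the compound at the concentration tested), compound 1 gives 79%, and compound 2 gives 91%, the highest of the two numbers; the step of a number 12 percentage points higher from compound 1 to compound 2 (beyond the scatter) describes that one change. Compound 3 `COc1cc(C(=O)/C=C/c2cc(-c3cc(OC)c(OC)c(OC)c3)n[nH]2)cc(OC)c1OC` differs from compound 2 by methoxy in place of hydrogen on an aromatic carbon. Going by the values given here, no measured step concerns this change; the single step known involves a different group, so no direction can be drawn from it. With nothing to suggest a shift, compound 3 is expected to land close to compound 2, the estimated step being a number 1 percentage points lower from compound 2 to compound 3 (within the scatter), giving an expected value of 90%, within 75% to 100%.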

Compound 3, a percentage reported as activity, at one concentration (the size of the read-out at that concentration, not a potency): 97%
Beside the measured number, compound 3's estimate is 7 percentage points below it; the measured number falls inside the stated range.
By their numbers in this assay, from the lowest: compound 1; then compounds 2 and 3 (each within the scatter of the next).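

Methoxy in place of hydrogen on an aromatic carbon, ortho to a methoxy group, is the first change shown on this aryl group that keeps it methoxy-substituted: in this assay the step is a number 6 percentage points higher from compound 2 to compound 3 (within the scatter), so compound 2 and compound 3 cannot be told apart. This position therefore takes a methoxy group without a step beyond the scatter. No evidence on the cause of this result is available.

Still open, as far as these compounds go, is whether a different group at this position, such as a carboxylic acid or a chlorine atom, would give a step beyond the scatter. The compounds shown also leave open how the read-out behaves at other concentrations.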